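Sugar-bearing analogues of the shared core: step to compound 3

The source may report more compounds than this note shows. Statements on the series, on what has been measured and on what is new or still open speak of the compounds shown alone.

Two members of the series have numbers in a functional assay on HCT-116 cells (Homo sapiens) for cytotoxicity, read by MTT assay, with a stated time of 72 h; a higher number here means a weaker inhibitor, a lower number a stronger inhibitor. Compound 1 `CN1CCN(CCCCCn2c3c(c4ccccc42)C(=O)c2c[n+]([O-])c4ccccc4c2C3=O)CC1` carries a basic chain on the shared core and in this assay compound 1 gives 1220 nM. Compound 2 `CC1(C)O[C@@H](CO)[C@H](Cn2cc(Cn3c4c(c5ccccc53)C(=O)c3c[n+]([O-])c5ccccc5c3C4=O)nn2)O1` carries a protected sugar unit through a five-membered aromatic ring with 3 nitrogen, and in this assay compound 2 gives 130 nM, the lowest of the two numbers; the gap to compound 1 is beyond the scatter, so compound 2 is the stronger of the pair.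

Compound 3 `O=C1c2c[n+]([O-])c3ccccc3c2C(=O)c2c1c1ccccc1n2Cc1cn([C@@H]2C[C@H](O)[C@@H](CO)O2)nn1` is the next candidate. It differs from compound 2 in one place: 4-hydroxy-5-(hydroxymethyl)oxolan-2-yl in place of (5-(hydroxymethyl)-2,2-dimethyl-1,3-dioxolan-4-yl)methyl on an aromatic nitrogen. The group that enters sits on the aromatic nitrogen directly, without the methylene that carries the group that leaves. Among the measured compounds shown here, no measured pair changes this position, so no step size can be drawn from it. With compound 2 as the only anchor, the expected step is small, toward a somewhat higher number, with a range that also allows no change beyond the scatter; the estimate for compound 3 is 250 nM, between 80 nM and 800 nM, meaning an expected step of a 1.9-fold higher number from compound 2 to compound 3 (0.28 log units; within the scatter).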

Compound 3, half-maximal inhibitory concentration: 50 nM
The estimate for compound 3 lay 5.0-fold (0.70 log units) above the measured number, and the stated range ends above it.
By their numbers in this assay, from the lowest: compound 3; then compound 2; then compound 1.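

In this assay, among the compounds shown here, putting 4-hydroxy-5-(hydroxymethyl)oxolan-2-yl in place of (5-(hydroxymethyl)-2,2-dimethyl-1,3-dioxolan-4-yl)methyl on an aromatic nitrogen gives a 2.6-fold lower number from compound 2 to compound 3 (0.41 log units; beyond the scatter), the first step that can be read at this position: it is modest but beyond the scatter, and it shows that the number at this position responds to the group carried there. The step bundles several differences, as the entering group has fewer heavy atoms than the leaving group, 2 hydrogen-bond donors rather than 1, one ring hetero atom rather than 2, 3 defined stereocentres rather than 2, and no methylene between ring and aromatic nitrogen, so this single pair cannot assign the lower number to any one of them. No measurement at hand bears on what lies behind the step.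

The compounds shown leave open whether the methylene alone, the ring exchange or the free hydroxy groups carry the step. They also leave open how the number would respond to an amine in place of the hydroxy group on the oxolane ring, or to a carboxylic acid in place of the hydroxymethyl group.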